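A few compounds are considered here, and "the series" means these few. Any claim that something is new, unique, unknown or untested is made for them only; others in the source may bear on it.

Compound 1, with structure `COCCC1=C(N2CC2)C(=O)C(C)=C(N2CC2)C1=O`, is the weaker of the two compounds measured in a functional assay on L1210 cells (Mus musculus), with a stated time of 1 days (a lower number here means a less potent compound, a higher number a more potent compound, by a factor of ten per unit of this negative logarithm), where compound 1 gives 5.12. Within the data shown here, its only neighbour is compound 2, with structure `CC1=C(N2CC2)C(=O)C(N2CC2)=C(N2CC2)C1=O`; in this assay compound 2 gives 5.69, and the step of a number 0.57 log units higher from compound 1 to compound 2 (beyond the scatter) is the single measured step. Compound 3, with structure `CC1=C(N2CC2)C(=O)C(COc2ccccc2)=C(N2CC2)C1=O`, has not yet been measured in this assay. It differs from compound 1 in one place: phenoxy in place of methoxymethyl on a saturated chain carbon bound to a double-bonded ring carbon. Among the measured compounds shown here, the measured step from compound 1 to compound 2 concerns a different place, the double-bonded ring carbon, and therefore does not bear directly on the change that leads to compound 3; nothing among the measured compounds tells how exchanging methoxymethyl for phenoxy on the saturated chain carbon moves the number. For the measured compounds named here, with no relevant step to lean on, the expected step of a number 0.08 log units higher from compound 1 to compound 3 (within the scatter) is set at no change beyond the scatter, and the uncertainty is kept wide. Compound 3 is thus estimated at 5.2 in this assay, within a range of 4.5 to 5.9.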

Compound 3, logarithm of the reciprocal of the active concentration, log(1/C): 3.89
For compound 3 the middle estimate is 1.31 log units above the measured one; measured number outside the range, below it.
By their numbers in this assay, from the lowest: compound 3; then compound 1; then compound 2.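

In this assay, the saturated chain carbon bound to a double-bonded ring carbon proves sensitive to what it carries: phenoxy in place of methoxymethyl gives a number 1.23 log units lower from compound 1 to compound 3 (beyond the scatter). Among these compounds, the only earlier step, a number 0.57 log units higher from compound 1 to compound 2 (beyond the scatter), went upward and concerned the double-bonded ring carbon, so this is the first sign that a change on the chain can cost potency, and it does so while the counts of hydrogen-bond donors and acceptors and the net charge stay the same, with the entering group differing in its 7 heavy atoms against 3 and its one six-membered aromatic ring of carbon only. Nothing available here accounts for the fall.

The compounds shown leave open whether the aromatic ring itself or simply the larger group goes with the lower number, since a cyclohexyloxy group or a longer ether chain such as butoxy on the same carbon would separate the two. They also leave open how a hydroxyl group or an amine such as dimethylamino would fare at this place.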